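Hydroxy on the chain of compound 3

A few compounds are considered here, and "the series" means these few. Any claim that something is new, unique, unknown or untested is made for them only; others in the source may bear on it.

Compound 1 `CCCCC[C@@H](C[C@H](O)C[C@@H]1CC=CC(=O)O1)OC` gives 26300 nM
Compound 2 `CCCCC[C@@H](C[C@@H](O)C[C@@H]1CC=CC(=O)O1)OC` gives 46300 nM
Compound 3 `CCCCC[C@H](CCC[C@H]1CC=CC(=O)O1)OC` gives 12200 nM

a functional assay on A2780 ADR cells (Homo sapiens) for cytotoxicity, read by MTT assay, with a stated time of 24 h (a lower number here means a stronger inhibitor, a higher number a weaker inhibitor), supplies all three values, and compound 3 has the lowest number among them. The change hydroxy in place of hydrogen on a saturated chain carbon bound to two saturated chain carbons turns compound 3 into compound 4 `CCCCC[C@H](C[C@H](O)C[C@H]1CC=CC(=O)O1)OC` and is the step followed here. Going by the values given here, the one measured step is a 1.8-fold higher number from compound 1 to compound 2 (0.25 log units; within the scatter) and involves configuration only, so configuration is not expected to move the number much. Compound 1 at 26300 nM and compound 2 at 46300 nM both carry the hydroxy and both lie above compound 3, so a higher number is expected. The estimated change is a 2.5-fold higher number from compound 3 to compound 4 (0.39 log units; beyond the scatter) in this assay on this basis. Compound 4 is expected at 30000 nM with 13000 nM to 70000 nM as the estimated range of the measurement.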

Compound 4, half-maximal inhibitory concentration: 57500 nM
Compound 4: the middle estimate sits 1.9-fold (0.28 log units) below what was measured, within the range that was stated.
By their numbers in this assay, from the lowest: compound 3; then compounds 1, 2 and 4 (each within the scatter of the next, the first and the last beyond it).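

In this assay, hydroxy in place of hydrogen on a saturated chain carbon bound to two saturated chain carbons now has a direct step, a 4.7-fold higher number from compound 3 to compound 4 (0.67 log units; beyond the scatter), where compounds 1 and 2 gave only an indirect reading. Configuration is not uniformly silent among the hydroxy compounds: the full mirror image gives a 1.2-fold higher number from compound 2 to compound 4 (0.09 log units; within the scatter), yet a change at two stereo elements gives a 2.2-fold higher number from compound 1 to compound 4 (0.34 log units; beyond the scatter). That last gap is a matter of configuration alone: the fact that compounds 1 and 4 differ only in the configuration as drawn.

As far as these compounds go, whether an amine or a carboxylic acid at this carbon would follow hydroxy remains open. So does the size of the step from hydrogen in the other configurations.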